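An aromatic ring in place of 2-oxopiperidin-1-yl

The compounds below may be only part of what the source reports. "The series", "measured", "known", "first", "only" and "open" are said of these compounds alone.

Among the compounds with values here, in a functional assay (aorta) with Rattus norvegicus as the target (on this read-out higher numbers stand for an effect only at larger amounts of compound and lower numbers for an effect already at smaller amounts), compound 2 `N#Cc1ccc2c(c1)[C@@H](N1CCCCC1=O)[C@H](O)C(CF)(CF)O2` gives 8.91 nM, the lowest number so far, and compound 1 `N#Cc1ccc2c(c1)[C@@H](N1CCCC1=O)[C@H](O)C(CF)(CF)O2` gives 85.1 nM. Compound 3 `N#Cc1ccc2c(c1)[C@@H](n1ccccc1=O)[C@H](O)C(CF)(CF)O2` differs from compound 2 on a saturated ring carbon: a group of 7 heavy atoms (5 carbon, 1 nitrogen, 1 oxygen; one six-membered aromatic ring with 1 hetero atom) in place of a group of 7 heavy atoms (5 carbon, 1 nitrogen, 1 oxygen; one six-membered non-aromatic ring with 1 hetero atom), on a saturated ring carbon. Within the data shown here, the only measured step at this place, a 9.6-fold lower number from compound 1 to compound 2 (0.98 log units; beyond the scatter), was modest and came with a change of ring size, which compound 3 does not make. No step beyond the scatter is therefore expected, and the expected step is a 1.3-fold lower number from compound 2 to compound 3 (0.10 log units; within the scatter). The estimate for compound 3 is 7 nM, with an expected range of 1.8 nM to 28 nM.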

Compound 3, half-maximal effective concentration: 148 nM
For compound 3 the middle estimate is 21-fold (1.33 log units) below the measured one; the whole stated range lies below it.
By their numbers in this assay, from the lowest: compound 2; then compounds 1 and 3 (each within the scatter of the next).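

In this assay, the 2-oxopiperidin-1-yl group on this saturated ring carbon does not tolerate exchange for the aromatic six-membered ring, with a 17-fold higher number from compound 2 to compound 3 (1.22 log units; beyond the scatter) at unchanged ring size, so ring size alone does not set the number here. The aromatic ring also does not separate from 2-oxopyrrolidin-1-yl, with a 1.7-fold higher number from compound 1 to compound 3 (0.24 log units; within the scatter). Nothing available accounts for this loss. The compounds shown leave open how a piperidin-1-yl ring without the carbonyl, or an open-chain acetamido group, would read at this carbon. They also leave open whether a seven-membered lactam would extend the gain seen with the six-membered ring.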